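Cyano for methyl on the furoxan of a dihydropyridine

A few compounds are considered here, and "the series" means these few. Any claim that something is new, unique, unknown or untested is made for them only; others in the source may bear on it.

Compound 2 `COC(=O)C1=C(C)N=C(C)/C(=C(/O)OC)C1c1ccccc1OCc1c(C)no[n+]1[O-]` stands lowest of the three numbers measured in an assay on Cortex for displacement of a labelled ligand from Voltage-dependent L-type calcium channel subunit alpha-1D (Rattus norvegicus); a lower number here means a stronger inhibitor, a higher number a weaker inhibitor: compound 2 gives 72 nM. The nearest is compound 3 `COC(=O)C1=C(C)N=C(C)/C(=C(/O)OC)C1c1cccc(OCc2nonc2C#N)c1`, which in this assay gives 590 nM, and the furthest is compound 1 `COC(=O)C1=C(C)N=C(C)/C(=C(/O)OC)C1c1cccc(OCc2c(C(N)=O)no[n+]2[O-])c1`, which gives 3600 nM. Compound 4 `COC(=O)C1=C(C)N=C(C)/C(=C(/O)OC)C1c1ccccc1OCc1c(C#N)no[n+]1[O-]` is not yet measured; it arises from compound 2 by cyano in place of methyl on an aromatic carbon. For the measured compounds named here, only one measured step bears on it, and loosely: a 6.1-fold lower number from compound 1 to compound 3 (0.79 log units; beyond the scatter), where a cyano-bearing ring replaced a carboxamide-bearing ring on the chain carbon bound to the aromatic oxygen. Going by the values given here, compound 2 and compound 3 differ in more than one place, so their values show only that the methyl-bearing compound sits lower. Among the compounds with values here, since the single step toward a cyano group favoured the cyano compound, a small step downward or none beyond the scatter is expected; the expected step is a 1.4-fold lower number from compound 2 to compound 4 (0.16 log units; within the scatter). Compound 4 is therefore estimated at 50 nM, within a range of 15 nM to 160 nM.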

Compound 4, half-maximal inhibitory concentration: 67 nM
Compound 4: middle estimate off by 1.3-fold (0.13 log units), on the low side; measured number inside the range.
By their numbers in this assay, from the lowest: compounds 4 and 2 (each within the scatter of the next); then compound 3; then compound 1.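

Cyano in place of methyl on this aromatic carbon, next to the ring nitrogen, gives a 1.1-fold lower number from compound 2 to compound 4 (0.03 log units; within the scatter) in this assay, so on the core of compound 2 the two groups cannot be told apart. For the compounds shown here, the earlier compounds did not show this: compound 2 and compound 3 differ in more than one place, and the only earlier step, a 6.1-fold lower number from compound 1 to compound 3 (0.79 log units; beyond the scatter), set a cyano-bearing ring against a carboxamide-bearing ring, not against methyl. No measured evidence accompanies this result to account for the match between the two groups.

From the compounds shown here alone, whether an amine, a carboxylic acid or a longer chain on this carbon would stay close to compound 2 remains open. Also open, going by these compounds, is whether cyano and methyl would still match with the ring attached as in compound 1.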